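This account rests on a few compounds, and the source may have more. Where it says the series, first, only, none or still open, it means among the compounds named here.

Of the compounds shown here, three built on one shared core have been measured in a functional assay on A549 cells (Homo sapiens) for inhibition, read by MTT assay; a higher number here means a weaker inhibitor, a lower number a stronger inhibitor. Compound 1 `CCCCCCCCn1cc(/C=C/C(=O)c2ccc(NC(=O)CN3CCN(c4ccccc4)CC3)cc2)nn1` gives 52400 nM. Compound 2 `CCCCCCCCn1cc(/C=C/C(=O)c2ccc(NC(=O)CN3CCN(c4ccccc4F)CC3)cc2)nn1` carries a fluoro in place of hydrogen on an aromatic carbon and gives 47100 nM, a step of a 1.1-fold lower number from compound 1 to compound 2 (0.05 log units; within the scatter). Compound 3 `CCCCCCCCn1cc(/C=C/C(=O)c2ccc(NC(=O)CN3CCN(C(=O)OC(C)(C)C)CC3)cc2)nn1` carries tert-butoxycarbonyl in place of phenyl on an amine nitrogen in a ring and gives 43300 nM. The steps of a 1.2-fold lower number from compound 1 to compound 3 (0.08 log units; within the scatter) and a 1.1-fold lower number from compound 2 to compound 3 (0.04 log units; within the scatter) are both within the scatter, so compound 3 holds the lowest of the three numbers without standing apart from the other two.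

Compound 4 `CC(C)(C)OC(=O)N1CCN(CC(=O)Nc2ccc(C(=O)/C=C/c3cn(Cc4ccc(Br)cc4)nn3)cc2)CC1` has not been measured. It differs from compound 3 in one place: 4-bromophenyl in place of heptyl on a saturated chain carbon bound to an aromatic nitrogen. Within the data shown here, none of the measured steps touched this part of the molecule; all three changed the group on the amine nitrogen in the ring and all stayed within the scatter. Among the measured compounds shown here, no measured step therefore bears on this change, and the data give no direction for it. Compound 4 is expected to give about 40000 nM, with a range from 10000 nM to 160000 nM. The step of a 1.1-fold lower number from compound 3 to compound 4 (0.03 log units; within the scatter) is estimated to be small, though the uncertainty around it is wide.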

Compound 4, half-maximal inhibitory concentration: 38400 nM
Compound 4: middle estimate off by 1.0-fold (0.02 log units), on the high side, and the stated range covers the measured number.
By their numbers in this assay, from the lowest: compounds 4, 3, 2 and 1 (each within the scatter of the next).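

Replacing octyl with 4-bromobenzyl gives a 1.1-fold lower number from compound 3 to compound 4 (0.05 log units; within the scatter) in this assay, and this is the only change shown at this end of the molecule. At this position, then, a chain with no ring and a group with a six-membered aromatic ring carrying bromine cannot be told apart in this measurement, so the earlier finding of small steps on the amine nitrogen in the ring now extends to a second place on the shared core. Nothing measured here offers a reason for this result.

From the compounds shown here alone, it remains open whether another group at this position, such as a much shorter chain, an unsubstituted benzyl or a carboxylic acid, would move the number beyond the scatter. Going by these compounds, it is also open whether 4-bromobenzyl would read the same alongside the phenyl of compound 1 or the 2-fluorophenyl of compound 2.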